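Swapping the Benzyl Substituent in a Piperidine Series

This account rests on a few compounds, and the source may have more. Where it says the series, first, only, none or still open, it means among the compounds named here.

Compound 1 `O=c1c2cnn(-c3ccc(F)cc3)c2ncn1CC1(O)CCN(Cc2ccncc2)CC1` has "not determined" (no result reported) in an assay on Sf21 cells for inhibition of ubiquitin carboxyl-terminal hydrolase 7 (Homo sapiens), read by spectrophotometry, with stated times of 30 min and 2 h; on this read-out higher numbers stand for weaker inhibition and lower numbers for stronger inhibition. Compound 2 `O=c1c2cnn(-c3ccc(F)cc3)c2ncn1CC1(O)CCN(Cc2ccc(F)cc2Cl)CC1` gives 1600 nM in this assay, and compound 3 `COC(=O)c1ccc(CN2CCC(O)(Cn3cnc4c(cnn4-c4ccc(F)cc4)c3=O)CC2)c(Cl)c1` gives 800 nM; compound 3 thus holds the lower of the two numbers, yet the step of a 2.0-fold lower number from compound 2 to compound 3 (0.30 log units; within the scatter) stays within the scatter, so the two cannot be ranked. Compound 4 `N#Cc1cc(Cl)ccc1CN1CCC(O)(Cn2cnc3c(cnn3-c3ccc(F)cc3)c2=O)CC1` differs from compound 3 by 4-chloro-2-cyanophenyl in place of 2-chloro-4-(methoxycarbonyl)phenyl on a saturated chain carbon bound to an amine nitrogen in a ring. Going by the values given here, the only measured step, from compound 2 to compound 3, also altered a group on that aromatic ring and stayed within the scatter, so no move beyond the scatter is expected here either. Compound 4 is therefore expected to give about 900 nM in this assay, between 300 nM and 2700 nM, an expected step of a 1.1-fold higher number from compound 3 to compound 4 (0.05 log units; within the scatter).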

Compound 4, half-maximal inhibitory concentration: 11400 nM
The estimate for compound 4 lay 13-fold (1.10 log units) below the measured number; measured number outside the range, above it.
By their numbers in this assay, from the lowest: compounds 3 and 2 (each within the scatter of the next); then compound 4.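

Placing 4-chloro-2-cyanophenyl at this position gives a 14-fold higher number from compound 3 to compound 4 (1.15 log units; beyond the scatter) and a 7.1-fold higher number from compound 2 to compound 4 (0.85 log units; beyond the scatter) in this assay, so this site does respond to a change in the benzyl substituent, which the earlier step within the scatter did not show. The entering group differs from both earlier groups in two ways, with a nitrile on the ring and its chlorine named at a different ring position. No measurement shown explains the higher number.

Which of those two differences matters remains open. So does how a carboxylic acid or a primary amide would behave in place of the methoxycarbonyl group of compound 3.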